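Swapping the piperidine for a hydroxymethyl-bearing benzyl group

The compounds below may be only part of what the source reports. "The series", "measured", "known", "first", "only" and "open" are said of these compounds alone.

Compound 2, `Cc1noc(-c2nc(C)c3c(c2N)C(=O)N(CC2CCNCC2)C3=O)n1`, stands highest of the two numbers seen in a physicochemical assay for solubility, using the shake flask method, in simulated intestinal fluid, measured as kinetic solubility, with a stated time of 2 h, at 25 degrees C, at pH 6.5; on this read-out higher numbers stand for higher solubility and lower numbers for lower solubility: compound 2 gives 160000 nM, while compound 1, `COC(=O)c1nc(C)c2c(c1N)C(=O)N(Cc1ccccc1)C2=O`, gives 7400 nM. Compound 3, `Cc1noc(-c2nc(C)c3c(c2N)C(=O)N(Cc2ccccc2F)C3=O)n1`, reaches only a limit of the assay, < 5000 nM. Within the data shown here, the step of an at least 32-fold lower number from compound 2 to compound 3 (1.50 log units; beyond the scatter) is the one measured change of this kind, and it sits at the limit of < 5000 nM in this assay, at which 1 of the 3 values shown sits. Compound 4, `Cc1noc(-c2nc(C)c3c(c2N)C(=O)N(Cc2ccc(CO)cc2)C3=O)n1`, carries a related change: 4-(hydroxymethyl)phenyl in place of piperidin-4-yl on a saturated chain carbon bound to an amide-type nitrogen in a ring. The entering group again forms an aromatic ring of carbon only, so a large fall is expected, though the hydrogen-bond donor and acceptor it carries leave room for a smaller drop than that of compound 3. Compound 4 is therefore expected to give 8000 nM, between 2000 nM and 40000 nM, a step of a 20-fold lower number from compound 2 to compound 4 (1.30 log units; beyond the scatter).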

Compound 4, solubility: < 5000 nM
Compound 4: a limit, no number; the forecaster's own chance of this, stated with the estimate: 35%; at least 1.6-fold (0.20 log units) between middle value and limit.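

In this assay, a second entering group with an aromatic ring of carbon only, 4-(hydroxymethyl)phenyl, again brings a large fall at this place: an at least 32-fold lower number from compound 2 to compound 4 (1.50 log units; beyond the scatter). The value of compound 4 is a limit, not a number, as is that of compound 3, so the step between them cannot be read. The hydroxymethyl group does not bring compound 4 clear of the limit that compound 3 also reached: the limit of < 5000 nM in this assay, at which 2 of the 4 values shown sit.

Going by these compounds, whether an aminomethyl group or a carboxylic acid in place of the hydroxymethyl group would stay clear of that limit remains open.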